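The compounds below may be only part of what the source reports. "The series", "measured", "known", "first", "only" and "open" are said of these compounds alone.

Compound 1 `COc1ccccc1C1CCN(c2ccn3c(CC4CC4)nnc3c2Cl)CC1` was tested in an ADME assay on a cell-free system (plasma, Rattus norvegicus) for protein binding; a higher number here means a larger unbound share of the compound, a lower number a smaller unbound share. In this assay compound 1 gives < 0.01, which is a limit of the assay. Compound 2 `COc1ccc(F)cc1C1CCN(c2ccn3c(CC4CC4)nnc3c2Cl)CC1` carries fluoro in place of hydrogen on an aromatic carbon. In this assay compound 2 gives < 0.01, also a limit. The step that the two limits leave unreadable from compound 1 to compound 2 therefore cannot be read. Compound 3 `COc1c(F)cccc1C1CCN(c2ccn3c(CC4CC4)nnc3c2C(F)(F)F)CC1` has a different core; the difference between the two cores is not broken down here. In this assay compound 3 gives < 0.01, again a limit. Compound 4 `COc1c(F)ccc(F)c1C1CCN(c2ccn3c(CC4CC4)nnc3c2C(F)(F)F)CC1` is not yet measured and carries fluoro in place of hydrogen on an aromatic carbon. This is the same kind of change as from compound 1 to compound 2, but the place now lies ortho to a large group, meta to a methoxy group and para to a fluoro group, rather than meta to a large group and para to a methoxy group. Because (the limit of < 0.01 in this assay, at which 3 of the 3 values shown sit), the expected step is a step that the limit leaves unreadable from compound 3 to compound 4, again unreadable. Compound 4 is expected to give 0.005 in this assay.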

Compound 4, unbound fraction: < 0.01
Compound 4: no number, only a limit; the forecaster's own chance of this, stated with the estimate: 90%; the middle value is on the limit's open side.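

In this assay, compound 3 and compound 4 both sit at a limit, so the step between them cannot be read: the limit of < 0.01 in this assay, at which 4 of the 4 values shown sit.

The compounds shown leave open how large the unbound share of each one really is, and whether adding a fluoro changes it at all.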